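Working notes: from compound 3 to compound 4

The compounds below may be only part of what the source reports. "The series", "measured", "known", "first", "only" and "open" are said of these compounds alone.

Measured values in a functional assay on HepG2 cells (Homo sapiens) for antiproliferative activity, read by MTT assay, with a stated time of 48 h (on this read-out lower numbers stand for stronger inhibition and higher numbers for weaker inhibition), follow.
- compound 1 `COc1ccc(/C=C/c2cc(OC)cc(OC)c2/C=C/C(=O)c2ccc(Cl)c(Cl)c2)cc1` with 10.8 ug/mL
- compound 2 `CCCC(C)Oc1ccc(C(=O)/C=C/c2c(/C=C/c3ccc(OC)cc3)cc(OC)cc2OC)cc1` with 11.1 ug/mL
- compound 3 `COc1ccc(/C=C/c2cc(OC)cc(OC)c2/C=C/C(=O)c2ccc(Br)cc2)cc1` with 12.9 ug/mL

Compound 3 stands level with the other two within the scatter and has no rank of its own. The steps that show this are a 1.2-fold higher number from compound 1 to compound 3 (0.08 log units; within the scatter) and a 1.2-fold higher number from compound 2 to compound 3 (0.07 log units; within the scatter), and the remaining one is a 1.0-fold higher number from compound 1 to compound 2 (0.01 log units; within the scatter).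

Compound 4 `COc1ccc(/C=C/c2cc(OC)cc(OC)c2/C=C/C(=O)c2ccccc2C)cc1` differs from compound 3 by 2-methylphenyl in place of 4-bromophenyl on a carbonyl carbon. All three measured steps exchange the group on that same carbonyl carbon, so all three bear on this change, and each stayed within the scatter. For the measured compounds named here, no measured compound carries 2-methylphenyl, which limits how far these steps can be carried over. A step beyond the scatter is therefore not expected in this assay, and no direction is expected either. The estimated step is a 1.1-fold lower number from compound 3 to compound 4 (0.03 log units; within the scatter) and is expected to stay small. Compound 4 is estimated at 12 ug/mL, with an expected range from 6.5 ug/mL to 24 ug/mL.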

Compound 4, half-maximal inhibitory concentration: 5.3 ug/mL
Compound 4: middle estimate off by 2.3-fold (0.35 log units), on the high side; measured number outside the range, below it.
By their numbers in this assay, from the lowest: compound 4; then compounds 1, 2 and 3 (each within the scatter of the next).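

In this assay, the group on the carbonyl carbon now shifts the number beyond the scatter, which the exchanges among 4-bromophenyl, 4-(1-methylbutoxy)phenyl and 3,4-dichlorophenyl did not do: the new steps read a 2.4-fold lower number from compound 3 to compound 4 (0.39 log units; beyond the scatter) and a 2.1-fold lower number from compound 2 to compound 4 (0.32 log units; beyond the scatter) and a 2.0-fold lower number from compound 1 to compound 4 (0.31 log units; beyond the scatter) (all three modest in size). For the compounds shown here, compound 4, the only compound here with 2-methylphenyl, therefore separates from the other three and is the most potent of the four in this read-out, so this carbonyl substituent is not as indifferent as the first three compounds suggested. No supporting measurement accompanies these numbers, so the reason for the separation stays unknown.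

With a single 2-methylphenyl compound, the series cannot say whether the shift belongs to the methyl group, to its place on the ring, or to the absence of the substituents carried by compounds 1, 2 and 3. Unsubstituted phenyl, 4-methylphenyl, 2-bromophenyl and 2-methoxyphenyl on the same carbonyl carbon would separate these readings, and whether a longer chain such as 2-ethylphenyl keeps the shift also remains open.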